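This account rests on a few compounds, and the source may have more. Where it says the series, first, only, none or still open, it means among the compounds named here.

Working notes on the series in a functional assay on HCT-116 cells (Homo sapiens) for inhibition, read by CCK-8 assay, with a stated time of 72 h, tested at 2 uM; a lower number here means less inhibition of growth, a higher number more inhibition of growth at the concentration tested. Compound 1 (`COc1ccc(SCc2ccc(/C=C/C(=O)Nc3ccccc3N)cc2)cc1OC`) gives (12.9%), compound 2 (`Cc1cc(C)cc(SCc2ccc(/C=C/C(=O)Nc3ccccc3N)cc2)c1`) gives (7.98%) and compound 3 (`Nc1ccccc1NC(=O)/C=C/c1ccc(CSc2cccc(F)c2)cc1`) gives (7.95%). Compound 3 stands within the scatter of both other compounds, so the three cannot be ranked on these numbers.

Compound 4 (`CCc1ccc(SCc2ccc(/C=C/C(=O)Nc3ccccc3N)cc2)cc1`) carries 4-ethylphenyl in place of 3-fluorophenyl on a sulfur. The core is unchanged, and the exchange concerns the same place as all three measured steps. Those steps are (a number 4.9 percentage points lower from compound 1 to compound 2 (within the scatter)), (a number 5 percentage points lower from compound 1 to compound 3 (within the scatter)) and (a number 0 percentage points lower from compound 2 to compound 3 (within the scatter)), and each lies within the scatter. Among the measured compounds shown here, they span dimethoxy, dimethyl and fluoro variants of the phenyl on the sulfur, but none of the measured compounds has an ethyl group, so the series offers no direct precedent for 4-ethylphenyl.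

For the measured compounds named here, with the three steps at this place as the only guide, no step beyond the scatter is expected in this assay, and the direction stays open. The estimated step is small (a number 1.1 percentage points higher from compound 3 to compound 4 (within the scatter)) and lies within the scatter. For compound 4 the expected value is 9% with an estimated range from 2% to 19% in this read-out.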

Compound 4, percent growth inhibition at one concentration: 3.29%
Beside the measured number, compound 4's estimate is 5.7 percentage points above it, within the range that was stated.
By their numbers in this assay, from the lowest: compounds 4, 3, 2 and 1 (each within the scatter of the next).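

In this assay, replacing 3-fluorophenyl with 4-ethylphenyl on the sulfur gives a small step (a number 4.7 percentage points lower from compound 3 to compound 4 (within the scatter)), and the exchanges from the two disubstituted phenyl groups read (a number 4.7 percentage points lower from compound 2 to compound 4 (within the scatter)) and (a number 9.6 percentage points lower from compound 1 to compound 4 (within the scatter)). An ethyl-bearing phenyl therefore joins the dimethoxy, dimethyl and fluoro variants without a step beyond the scatter, so all six steps among these four compounds remain within it and the four cannot be ranked, even across the largest step, which ends at compound 4. No measurement at hand bears on the reason for these numbers.

As far as these compounds go, it remains open whether any exchange on this sulfur can produce a step beyond the scatter in this assay, for instance a phenyl carrying an amine, a carboxylic acid or a longer alkyl chain. From the compounds shown here alone, since the read-out comes from a single concentration, it also remains open whether these compounds would separate at other concentrations or in a full concentration-response measurement.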